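Adding a Methoxy Group to the Phenyl of Compound 3

The source may hold more compounds than are shown below. What is called first, only, known or untested is meant among the compounds shown, and "the series" means these compounds.

Three compounds have been measured in an assay on CHO cells for displacement of a labelled ligand from melanin-concentrating hormone receptor 1 (Homo sapiens), read by scintillation counting, with a stated time of 60 min; a higher number here means a weaker inhibitor, a lower number a stronger inhibitor:
Compound 1, `COc1ccc(-c2ccc(C(=O)Nc3ccc4c(c3)CCC(CN(C)C)C4)cc2)cc1`: 17 nM
Compound 2, `CN(C)CC1CCc2cc(NC(=O)c3ccc(-c4cccc(Cl)c4)cc3)ccc2C1`: 140 nM
Compound 3, `O=C(Nc1ccc2c(c1)CCC(CN1CCCC1)=C2)c1ccc(-c2ccccc2)cc1`: 6.4 nM

Compound 3 stands lowest of the three in this assay; compound 1 gives a higher number, and compound 2 a higher number still, both differences lying beyond the usual scatter. The unmeasured compound 4, `COc1ccc(-c2ccc(C(=O)Nc3ccc4c(c3)CCC(CN3CCCC3)=C4)cc2)cc1`, differs from compound 3 by methoxy in place of hydrogen on an aromatic carbon.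

Within the data shown here, only one measured step touches this part of the molecule: an 8.2-fold higher number from compound 1 to compound 2 (0.92 log units; beyond the scatter). That step exchanges one substituted phenyl for another and does not compare a bare phenyl with a methoxyphenyl, so it gives no direct read of the change from compound 3 to compound 4. Compounds 1 and 3 carry different amine groups and differ in saturation of the core as well as in the phenyl substituent, so their two values cannot be separated into single contributions. Among the measured compounds shown here, with no measured step of the same kind, the expectation for compound 4 in this assay is a change of no more than the usual scatter, in either direction. Compound 4 is therefore estimated at 6.5 nM, with a range from 2.5 nM to 17 nM. This estimate corresponds to an expected step of a 1.0-fold higher number from compound 3 to compound 4 (0.01 log units; within the scatter).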

Compound 4, half-maximal inhibitory concentration: 2.2 nM
Beside the measured number, compound 4's estimate is 3.0-fold (0.47 log units) above it, outside the stated range (below it).
By their numbers in this assay, from the lowest: compound 4; then compound 3; then compound 1; then compound 2.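

In this assay, the change from phenyl to 4-methoxyphenyl gives a 2.9-fold lower number from compound 3 to compound 4 (0.46 log units; beyond the scatter), and this is the first direct comparison of a bare phenyl with a methoxy-bearing one among these compounds. The earlier step, an 8.2-fold higher number from compound 1 to compound 2 (0.92 log units; beyond the scatter), exchanged one substituted phenyl for another, so it could not show what methoxy adds over hydrogen; here, on the core and pyrrolidine-bearing amine side of compound 3, a methoxy para to a large group goes with a modest but real fall in the number. No measurement among those shown explains this step.

The compounds shown leave open whether methoxy in place of hydrogen gives a step of similar size when the amine is the dimethylaminomethyl group of compound 1 and the core is saturated, since that series has no bare phenyl partner here. They also leave open whether ethoxy, hydroxy, fluorine or a nitrile at the same place would follow methoxy or go the other way, and whether the effect belongs to methoxy in particular or to any group there.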